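This account rests on a few compounds, and the source may have more. Where it says the series, first, only, none or still open, it means among the compounds named here.

Of the compounds shown here, three that share one core have been measured in a functional assay on U2OS cells with metabotropic glutamate receptor 5 (Homo sapiens) as the target, read by calcium flux; a higher number here means a larger maximal response, a lower number a smaller maximal response. Compound 1, `Fc1ccc(-c2noc(C3CCc4c(nnn4C4CCCC4)C3)n2)cc1`, was run twice and gives 78%; 103% (2 entries); these two entries, (the several entries of compound 1 in this assay, 78%; 103% (2 entries)), do not settle on a single number. Compound 2, `CC1(n2nnc3c2CCC(c2nc(-c4ccc(F)cc4)no2)C3)CCOCC1`, gives 103% in this assay. Compound 3, `CC(C)Cc1noc(C2CCc3c(nnn3C(C)(C)C)C2)n1`, gives 66% and so stands lowest of the two single numbers available; compound 2 lies above it by a gap beyond the usual scatter, and compound 1 offers no single number to set beside it.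

Compound 4, `CN(C)c1ccc(-c2noc(C3CCc4c(nnn4C(C)(C)C)C3)n2)cc1`, has not yet been measured. It differs from compound 3 in one place: 4-(dimethylamino)phenyl in place of isobutyl on an aromatic carbon. Going by the values given here, no step between two measured compounds sizes this change directly. Compound 1 and compound 2 carry a 4-fluorophenyl group rather than an isobutyl, and compound 2 reaches 103%. The step is expected to be upward, a number 29 percentage points higher from compound 3 to compound 4 (beyond the scatter), beyond the scatter. Compound 4 is expected to give 95% in this assay, within a range from 70% to 115%.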

Compound 4, largest response reached (reported as percent of maximum), in percent of the reference or control that the assay uses: 68%
Compound 4: middle estimate off by 27 percentage points, on the high side; the measured number lies below the stated range.
By their numbers in this assay, from the lowest: compounds 3 and 4 (each within the scatter of the next); then compound 2.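

In this assay, putting 4-(dimethylamino)phenyl in place of isobutyl on this aromatic carbon gives a number 2 percentage points higher from compound 3 to compound 4 (within the scatter), so the maximal response does not separate the two compounds. Going by these compounds alone, this is the first direct one-place reading at this position, and it shows that a chain without a ring and a larger group carrying an aromatic ring can give matching responses here. Nothing in the data bears on why the response stays level across this change.

A single pair cannot show whether this level response holds for other groups on this carbon. Going by these compounds, what a plain phenyl ring, a methyl group or a carboxylic acid would give at this position remains open, as does the effect of any of these on a different group on the core.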